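This account rests on a few compounds, and the source may have more. Where it says the series, first, only, none or still open, it means among the compounds named here.

Measured so far in an assay on isolated protein for inhibition of Amine oxidase [flavin-containing] B (Homo sapiens), read by Amplex Red, with a stated time of 15 min; on this read-out higher numbers stand for weaker inhibition and lower numbers for stronger inhibition:

compound 1 `CC(=O)c1ccc(OCc2ccccc2F)cc1` gives 56.9 nM
compound 2 `CC(=O)c1ccc(OCc2ccc(F)cc2F)cc1` gives 27.3 nM
compound 3 `CC(=O)c1ccc(OCc2ccc(F)c(F)c2)cc1` gives 67.9 nM

Compound 4 `CC(=O)c1ccc(OCc2cc(F)c(F)c(F)c2)cc1` has not yet been measured in this assay. The change from compound 1 to compound 2 is fluoro in place of hydrogen on an aromatic carbon and gave a 2.1-fold lower number from compound 1 to compound 2 (0.32 log units; beyond the scatter). The change from compound 3 to compound 4 is fluoro in place of hydrogen on an aromatic carbon, the same kind of change, but the entering fluoro now sits ortho to a fluoro group, meta to a fluoro group and meta to a large group, whereas in compound 2 it sits meta to a fluoro group and para to a large group. The difference between the cores of compound 1 and compound 3 is not broken down here. Compound 3 and compound 1 lie within the scatter of each other, while compound 3 stands beyond the scatter from compound 2. A step in the same direction but smaller is expected, a 1.5-fold lower number from compound 3 to compound 4 (0.18 log units; within the scatter), since the surroundings differ from those that gave a 2.1-fold lower number from compound 1 to compound 2 (0.32 log units; beyond the scatter). Compound 4 is expected at 45 nM, within a range from 20 nM to 110 nM.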

Compound 4, half-maximal inhibitory concentration: 84.1 nM
Compound 4: the middle estimate sits 1.9-fold (0.27 log units) below what was measured; the range from low to high includes it.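

In this assay, fluoro in place of hydrogen on an aromatic carbon gives a 1.2-fold higher number from compound 3 to compound 4 (0.09 log units; within the scatter), a step that stays within the scatter. Set beside the earlier step, it cannot be told apart from it: the same change on two cores in this assay, a 2.1-fold lower number (0.32 log units; beyond the scatter) from compound 1 to compound 2 and a 1.2-fold higher number (0.09 log units; within the scatter) from compound 3 to compound 4, 2.6-fold (0.41 log units) apart, within the scatter of two such steps. The pair therefore does not show that the change carries over from one core to another, nor that it fails to, and no rule for this change can be stated from two steps.

The compounds shown vary only in fluoro groups on one aromatic ring. Open, going by these compounds, are how chloro, methoxy or nitrile would read in place of fluoro, and what an amide or an amine would do in place of the acetyl group.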